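Swapping an ether chain for a benzylic alcohol on a shared core

A few compounds are considered here, and "the series" means these few. Any claim that something is new, unique, unknown or untested is made for them only; others in the source may bear on it.

Measured compounds:
- Compound 1, `N#Cc1ccn2c(-c3ccccc3)c(-c3ccccc3)c(OCc3cccc(Cl)c3)c2c1`: "not determined" (no result reported)
- Compound 2, `N#Cc1ccn2c(-c3ccccc3)c(-c3ccccc3)c(OCOCc3ccccc3)c2c1`: 39000 nM
- Compound 3, `COc1ccc(COc2c(-c3ccccc3)c(-c3ccccc3)n3ccc(C#N)cc23)cc1`: "not determined" (no result reported)

Only one number is known among these three. In an assay for inhibition of Polyunsaturated fatty acid lipoxygenase ALOX15 (Oryctolagus cuniculus) (a higher number here means a weaker inhibitor, a lower number a stronger inhibitor), compound 2 gives 39000 nM, and compound 1 and compound 3 carry no result in this assay, so compound 2 stands alone as the sole reference point, and it is a weak inhibitor.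

The next compound, compound 4, `N#Cc1ccn2c(-c3ccccc3)c(-c3ccccc3)c(C(O)c3ccccc3)c2c1`, keeps the shared core and changes one group on the five-membered ring: hydroxy(phenyl)methyl in place of (benzyloxy)methoxy on an aromatic carbon. Going by the values given here, no step between two measured compounds is available to show how this part of the molecule responds to change.

Among the compounds with values here, with only a single value in hand, a modest shift in either direction, or none beyond the scatter, is the most that can be expected in this assay. Compound 4 is expected to give 30000 nM, within 8000 nM to 120000 nM. The estimated step of a 1.3-fold lower number from compound 2 to compound 4 (0.11 log units; within the scatter) is expected to stay close to the scatter.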

Compound 4, half-maximal inhibitory concentration: 48000 nM
Compound 4: middle estimate off by 1.6-fold (0.20 log units), on the low side; the range from low to high includes it.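

The first step readable at this position is a 1.2-fold higher number from compound 2 to compound 4 (0.09 log units; within the scatter) in this assay, so this assay does not tell these two groups apart. This holds even though the groups differ in their counts: (benzyloxy)methoxy has 10 heavy atoms and 0 hydrogen-bond donors, while hydroxy(phenyl)methyl has 8 heavy atoms and 1 hydrogen-bond donor, and each carries one six-membered aromatic ring of carbon only. No available measurement offers a reason for this result.

As far as these compounds go, both groups carry that aromatic ring, so it remains open whether a group without one, such as an amine or a carboxylic acid, would give a clearly different number on this aromatic carbon. Also open, from the compounds shown here alone, is whether a longer chain ending in a phenyl ring would move the number beyond the scatter.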